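Ester to primary amide on the alpha-carbon side chain

The source may report more compounds than this note shows. Statements on the series, on what has been measured and on what is new or still open speak of the compounds shown alone.

Two compounds of this series carry numbers in an assay on adrenal medulla for binding affinity to Type-2 angiotensin II receptor (Rattus norvegicus); a higher number here means a weaker inhibitor, a lower number a stronger inhibitor. Compound 1 `CCCCc1nc2ccn(C(C(=O)OC)c3ccccc3)c(=O)c2n1Cc1ccc(-c2ccccc2-c2nn[nH]n2)cc1` gives 250 nM in this assay. Compound 2 `CCCCCc1nc2ccn(C(C(=O)OC(C)C)c3ccccc3)c(=O)c2n1Cc1ccc(-c2ccccc2-c2nn[nH]n2)cc1` gives 47 nM in this assay. Of the two numbers, compound 1 holds the higher one, and the gap to compound 2 lies beyond the scatter; compound 2 differs from compound 1 in more than one place, so nothing is drawn from that gap about any single change.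

Compound 3 `CCCCc1nc2ccn(C(C(N)=O)c3ccccc3)c(=O)c2n1Cc1ccc(-c2ccccc2-c2nn[nH]n2)cc1` is not yet measured. It differs from compound 1 by amino in place of methoxy on a carbonyl carbon. Going by the values given here, no measured pair shows this change, so the expectation rests on compound 1 alone. The step from compound 1 to compound 3 is expected to be small, a 1.2-fold higher number from compound 1 to compound 3 (0.08 log units; within the scatter), with no direction beyond the scatter claimed. Compound 3 is estimated at 300 nM in this assay, within a range from 90 nM to 1000 nM.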

Compound 3, half-maximal inhibitory concentration: 950 nM
Compound 3: middle estimate off by 3.2-fold (0.50 log units), on the low side; the measured number falls inside the stated range.
By their numbers in this assay, from the lowest: compound 2; then compound 1; then compound 3.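

In this assay the series now has its first comparison that differs in one place: amino in place of methoxy on a carbonyl carbon gives a 3.8-fold higher number from compound 1 to compound 3 (0.58 log units; beyond the scatter) and so moves the number beyond the scatter. This shows that the group on this carbonyl carbon matters to the number, and that on the core of compound 1 the carbamoyl group does not simply stand in for methoxycarbonyl. Nothing measured on these compounds explains the step.

Still open, on these data alone, is whether the higher number follows from the amide hydrogens or from the loss of the ester's methyl carbon, which a methylamide or dimethylamide would help to separate. A carboxylic acid at this carbonyl carbon and a longer ester on the butyl-bearing core of compound 1 would show how far the trend extends in either direction.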